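Swapping nitro for chloro on compound 2

This account rests on a few compounds, and the source may have more. Where it says the series, first, only, none or still open, it means among the compounds named here.

Measured in a functional assay on NCI-H1975 cells (Homo sapiens) for cytotoxicity, read by MTT assay, with a stated time of 72 h; on this read-out lower numbers stand for stronger inhibition and higher numbers for weaker inhibition:
Compound 1 `OCCNc1ccc(Nc2ncc3nc(Nc4ccccc4)n(C4CCCC4)c3n2)cc1`: 2810 nM
Compound 2 `CN1CCN(c2ccc(Nc3ncc4nc(Nc5cccc([N+](=O)[O-])c5)n(C5CCCC5)c4n3)cc2)CC1`: 980 nM

Compound 2 holds the lower of the two numbers at 980 nM, and that gap to compound 1 at 2810 nM lies beyond the usual scatter. Compound 3 `CN1CCN(c2ccc(Nc3ncc4nc(Nc5cccc(Cl)c5)n(C5CCCC5)c4n3)cc2)CC1` changes compound 2 in one place: chloro in place of nitro on an aromatic carbon. Within the data shown here, no measured pair shows this change, so the expectation is only a cautious one: no step beyond the scatter in this assay. The expected move is small, an estimated 1.4-fold lower number from compound 2 to compound 3 (0.15 log units; within the scatter). For compound 3 the estimated value is 700 nM, with an expected range from 250 nM to 2000 nM.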

Compound 3, half-maximal inhibitory concentration: 390 nM
The estimate for compound 3 lay 1.8-fold (0.25 log units) above the measured number; the range from low to high includes it.
By their numbers in this assay, from the lowest: compound 3; then compound 2; then compound 1.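

In this assay, the nitro group of compound 2 is not required at this place on the ring: chloro gives a lower number (a 2.5-fold lower number from compound 2 to compound 3 (0.40 log units; beyond the scatter)), a modest step beyond the scatter. Among these compounds, this is the first pair differing in only one place, so this change can be read directly, and one chlorine atom outperforms the three heavy atoms of nitro. No available evidence gives a reason for the step. From the compounds shown here alone, whether a methoxy group, an amine or a bromine atom in that same place would give a lower number remains open.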